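The compounds below may be only part of what the source reports. "The series", "measured", "known", "first", "only" and "open" are said of these compounds alone.

Compound 2 `CCC(C)(C)Cc1c[nH]c(CCc2ccc(-n3ncnn3)cc2)n1` gives 205 nM in an in vitro assay on CHO cells for displacement of a labelled ligand from Bombesin receptor subtype-3 (Homo sapiens), read by scintillation counting, with a stated time of 2 h; a lower number here means a stronger inhibitor, a higher number a weaker inhibitor. Compound 1 `c1ccc(-c2ccc(CCc3nc(CC4CCCC4)c[nH]3)cc2)nc1` gives 177 nM in this assay, and compound 3 `CCC(C)(C)Cc1c[nH]c(CCc2ccc(-c3cccc(C#N)n3)cc2)n1` gives 140 nM, so all three numbers sit within the scatter of one another. Compound 4 `CCC(C)(C)Cc1c[nH]c(CCc2ccc(-c3cccc(C)n3)cc2)n1` differs from compound 2 in one place: 6-methylpyridin-2-yl in place of 2H-tetrazol-2-yl on an aromatic carbon. Among the compounds with values here, the only measured step that bears on this change is the related one from compound 2 to compound 3, where a six-membered ring with one hetero atom also replaced the 2H-tetrazol-2-yl, giving a 1.5-fold lower number from compound 2 to compound 3 (0.17 log units; within the scatter). Within the data shown here, no step therefore points beyond the scatter, and compound 4 is expected to sit close to compound 2, with an estimated step of a 1.4-fold lower number from compound 2 to compound 4 (0.14 log units; within the scatter). In this assay compound 4 is estimated at 150 nM, within a range of 60 nM to 380 nM.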

Compound 4, half-maximal inhibitory concentration: 6.3 nM
Estimate against measurement, compound 4: 24-fold (1.38 log units) above, outside the stated range (below it).
By their numbers in this assay, from the lowest: compound 4; then compounds 3, 1 and 2 (each within the scatter of the next).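

In this assay the change to 6-methylpyridin-2-yl gives a 33-fold lower number from compound 2 to compound 4 (1.51 log units; beyond the scatter) and thus shows that this place, para to a large group, can move the number far beyond the scatter. The step of a 22-fold lower number from compound 3 to compound 4 (1.35 log units; beyond the scatter) shows that the group on the six-membered ring decides the outcome, since methyl and cyano on that ring part widely. Nothing shown explains this gain. As far as these compounds go, whether an ethyl, a methoxy or an amine in place of that methyl would keep the low number remains open. So does whether the methyl would bring the same gain on the core of compound 1.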